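Swapping furanyl for pyridinyl on the shared core

The source may report more compounds than this note shows. Statements on the series, on what has been measured and on what is new or still open speak of the compounds shown alone.

Compound 2 `Oc1cccc(-c2cc(-c3ccco3)cc(-c3ccccc3O)n2)c1` holds the only measured number in a functional assay on T47D cells (Homo sapiens) for cytotoxicity, read by CCK-8 assay (a lower number here means a stronger inhibitor, a higher number a weaker inhibitor), among the compounds shown: compound 2 gives 820 nM. Compound 1 `Oc1ccccc1-c1cc(-c2ccco2)cc(-c2ccccc2O)n1` is reported only as a limit of the assay, > 50000 nM (the limit of > 50000 nM in this assay, at which 1 of the 2 values shown sits). For the measured compounds named here, the single measured step, an at least 60-fold lower number from compound 1 to compound 2 (1.78 log units; beyond the scatter), concerns the position of the hydroxyl on one phenyl group and not the five-membered ring that is varied next. Compound 3 `Oc1cccc(-c2cc(-c3cccnc3)cc(-c3ccccc3O)n2)c1` differs from compound 2 in one place: pyridin-3-yl in place of furan-2-yl on an aromatic carbon. Going by the values given here, no measured step touches this position. The measured step shows how large a single change can be on this core, but it gives no direction for the present exchange. A step within the scatter, or at most a modest one in either direction, is therefore expected, a 1.2-fold higher number from compound 2 to compound 3 (0.09 log units; within the scatter). Compound 3 is estimated at 1000 nM, with a range from 300 nM to 4000 nM.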

Compound 3, half-maximal inhibitory concentration: 6230 nM
Compound 3: middle estimate off by 6.2-fold (0.79 log units), on the low side; the whole stated range lies below it.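

In this assay, pyridin-3-yl in place of furan-2-yl on the shared core gives a 7.6-fold higher number from compound 2 to compound 3 (0.88 log units; beyond the scatter). The position opposite the ring nitrogen, which the earlier step did not touch, therefore responds to the group it carries, and of the two groups measured there, furan-2-yl goes with the lower number, even though both groups count the same hydrogen-bond donors and acceptors. Nothing at hand bears on what lies behind this step.

The two rings differ in both size and hetero atom, so the compounds shown leave open which of these differences carries the step. They also leave open how a plain phenyl, a thiophen-2-yl or an amine would fare at this position.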